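The source may report more compounds than this note shows. Statements on the series, on what has been measured and on what is new or still open speak of the compounds shown alone.

Compound 1 `CC1(C)CC(=O)C=C(Nc2ccc(Cl)cc2)C1` and compound 3 `CC1(C)CC(=O)C=C(Nc2ccc(Br)cc2)C1` form a closely matched pair: they are alike in every part but one, and that one difference is bromo in place of chloro on an aromatic carbon. Compound 2 `CC(=O)OC[C@H]1O[C@@H](SC(=S)C2=C(Nc3ccc(Cl)cc3)CC(C)(C)CC2=O)[C@H](OC(C)=O)[C@@H](OC(C)=O)[C@@H]1OC(C)=O` carries a much larger attachment on a core resembling that of compound 1; how the two cores differ is not broken down here. Compound 4 `CC(=O)OC[C@H]1O[C@@H](SC(=S)C2=C(Nc3ccc(Br)cc3)CC(C)(C)CC2=O)[C@H](OC(C)=O)[C@@H](OC(C)=O)[C@@H]1OC(C)=O` has not yet been tested and stands to compound 2 as compound 3 stands to compound 1. Their difference is bromo in place of chloro on an aromatic carbon, and the place given for it reads the same, word for word, as for the earlier pair, so this is the same change made on a bigger molecule.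

In a functional assay on J774.2 cells (Mus musculus) for inhibition, read by Griess assay, with a stated time of 24 h (a lower number here means a stronger inhibitor, a higher number a weaker inhibitor), compound 1 gives 63.8 ug/mL, and compound 3 gives 49.1 ug/mL. Between them the swap made a 1.3-fold lower number from compound 1 to compound 3 (0.11 log units; within the scatter). In this assay compound 2 gives 44.3 ug/mL, and all three numbers sit within the usual scatter of one another, so no order among them can be read.

For compound 4 the step expected is a 1.1-fold lower number from compound 2 to compound 4 (0.04 log units; within the scatter). That expectation rests on compound 1 and compound 3, whose pair gave a 1.3-fold lower number from compound 1 to compound 3 (0.11 log units; within the scatter), a step inside the scatter, and on nothing else, since this change has been seen only once. Compound 4 is therefore estimated at 40 ug/mL, with a likely range from 24 ug/mL to 68 ug/mL.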

Compound 4, half-maximal inhibitory concentration: 7.7 ug/mL
Compound 4: the middle estimate sits 5.2-fold (0.72 log units) above what was measured, and the stated range ends above it.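

In this assay the swap of chloro for bromo on the larger molecule gave a 5.8-fold lower number from compound 2 to compound 4 (0.76 log units; beyond the scatter) and so made a clear difference, while the same swap on the smaller molecule stayed within the scatter. The change therefore did not carry over from one core to the other with the same size, and a step read on the small core was a poor guide to the step on the large one: the same change on two cores in this assay, a 1.3-fold lower number (0.11 log units; within the scatter) from compound 1 to compound 3 and a 5.8-fold lower number (0.76 log units; beyond the scatter) from compound 2 to compound 4, 4.4-fold (0.65 log units) apart, beyond the scatter of two such steps. Among the compounds shown here, this rests on a single pair for each core, so it shows only that the two steps differ in these four compounds; it does not show which part of the large attachment goes with the bigger step, or why the two steps differ.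

The compounds shown leave open whether another group in the same place, such as fluoro, methoxy or an amine, would give a step closer to the one on the small core or the one on the large core. They also leave open whether a much smaller attachment on the same core, such as a methyl ester, would give the large step or the small one.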